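Piperazine aryl swap on the trifluoromethylpyridine amide series

This account rests on a few compounds, and the source may have more. Where it says the series, first, only, none or still open, it means among the compounds named here.

Measured so far:
compound 1 `CC1CCC(Nc2nc(C(F)(F)F)ccc2CNC(=O)C(C)c2ccc(NS(C)(=O)=O)c(F)c2)CC1`: 1130 nM in a functional assay on CHO-K1 cells for antagonist activity at transient receptor potential cation channel subfamily V member 1 (Homo sapiens), read by FLIPR; a higher number here means a weaker inhibitor, a lower number a stronger inhibitor
compound 2 `CC(C(=O)NCc1ccc(C(F)(F)F)nc1N1CCC(C(=O)c2ccc(F)cc2)CC1)c1ccc(NS(C)(=O)=O)c(F)c1`: 990 nM in this assay
compound 3 `Cc1cccc(N2CCN(c3nc(C(F)(F)F)ccc3CNC(=O)C(C)c3ccc(NS(C)(=O)=O)c(F)c3)CC2)c1`: 39.2 nM in this assay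

All three share the core and the methanesulfonamide-bearing propanamide arm; they differ in the group on the pyridine nitrogen side. Compound 3 has the lowest number of the three in this assay. Its nearest neighbour is compound 2, whose value sits beyond the scatter above it; compound 1 is further still, also beyond the scatter. Compound 3 is thus the strongest inhibitor of the measured set.

The next compound, compound 4 `CC(C(=O)NCc1ccc(C(F)(F)F)nc1N1CCN(c2ncccc2Cl)CC1)c1ccc(NS(C)(=O)=O)c(F)c1`, keeps the piperazine of compound 3 and changes only the group on it: 3-chloropyridin-2-yl in place of 3-methylphenyl on an amine nitrogen in a ring. Among the measured compounds shown here, no measured pair shows this exact swap, so there is no step to lean on. With the ring and atom count preserved, a modest step toward a weaker inhibitor is expected, estimated as a 1.7-fold higher number from compound 3 to compound 4 (0.22 log units; within the scatter). Compound 4 is therefore estimated at 65 nM in this assay, with a range from 15 nM to 280 nM.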

Compound 4, half-maximal inhibitory concentration: 117 nM
Compound 4: middle estimate off by 1.8-fold (0.26 log units), on the low side, and the stated range covers the measured number.
By their numbers in this assay, from the lowest: compound 3; then compound 4; then compounds 2 and 1 (each within the scatter of the next).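

Working notes: this is the first measured step at this position. In this assay, 3-chloropyridin-2-yl in place of 3-methylphenyl on an amine nitrogen in a ring gives a 3.0-fold higher number from compound 3 to compound 4 (0.47 log units; beyond the scatter), a modest move toward weaker inhibition, but one that lies beyond the scatter. The position therefore distinguishes between these two groups even though the heavy-atom count and the single six-membered aromatic ring are preserved, while the swap changes the ring atoms, replaces the methyl with chlorine and adds a hydrogen-bond acceptor all at once. No measurement on hand bears on what lies behind the step.

This single step cannot assign the change to the ring nitrogen or to the chlorine, and 3-chlorophenyl and pyridin-2-yl on the same amine nitrogen would separate the two. Also open, as far as these compounds go, is how the position responds to a non-aromatic group such as cyclohexyl, or to a small substituent such as methoxy or nitrile on the aromatic ring.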